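The source may report more compounds than this note shows. Statements on the series, on what has been measured and on what is new or still open speak of the compounds shown alone.

Measured compounds, each value being a limit of the assay, in a functional assay on cells (Platelet, Homo sapiens) for inhibition (on this read-out higher numbers stand for weaker inhibition and lower numbers for stronger inhibition), throughout:
- Compound 1 `COC(=O)c1ccc(-c2nn(Cc3ccccc3)c3ccccc23)cc1` gives > 10000 nM as a limit
- Compound 2 `CCCNC(=O)c1ccc(-c2nn(Cc3ccccc3)c3ccccc23)cc1` gives > 10000 nM as a limit
- Compound 3 `CC(C)NC(=O)c1ccc(-c2nn(Cc3ccccc3)c3ccccc23)cc1` gives > 10000 nM as a limit

Compound 3 has no number of its own, only this limit, and the whole series shares that position (the limit of > 10000 nM in this assay, at which 3 of the 3 values shown sit). In compound 4 `OCc1ccc(-c2nn(Cc3ccccc3)c3ccccc23)cc1` there is hydroxymethyl in place of isopropylcarbamoyl on an aromatic carbon, para to a large group (hydroxymethyl in place of isopropylcarbamoyl on an aromatic carbon). The nearest measured changes are a step that the two limits leave unreadable from compound 1 to compound 2 and a step that the two limits leave unreadable from compound 1 to compound 3 at the same carbonyl carbon, along with a step that the two limits leave unreadable from compound 2 to compound 3 on the amide nitrogen. None of them has a readable size, so no size can be carried over, and no firm step beyond the scatter is expected in this assay for this change. Compound 4 is expected to stay close to the limit of compound 3 (> 10000 nM), though a measurable value cannot be excluded. The expected change is a number no higher from compound 3 to compound 4 (the limit leaves the size open) in this estimate. For compound 4 the estimated value is 10000 nM with an expected range from 3000 nM to 30000 nM on this read-out.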

Compound 4, half-maximal inhibitory concentration: > 10000 nM
Compound 4: no number, only a limit; the forecaster's own chance of this, stated with the estimate: 70%; the middle value lies on the limit itself.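

In this assay, within the data shown here, compound 4 gives only a limit, as do compound 1, compound 2 and compound 3, so no step among them can be read: the limit of > 10000 nM in this assay, at which 4 of the 4 values shown sit. The compounds shown leave open how strongly each inhibits and whether any of these changes alters inhibition.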